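Swapping benzyl for methyl on the ester of compound 3

The source may report more compounds than this note shows. Statements on the series, on what has been measured and on what is new or still open speak of the compounds shown alone.

The study measures an ADME assay on WI-38 cells (Homo sapiens) for inhibition, read by CellTiter-Glo, with a stated time of 48 h, tested at 100 uM; on this read-out higher numbers stand for more inhibition at the one concentration tested (going by the name of the read-out) and lower numbers for less inhibition. Compound 1, with the structure `COC(=O)/C=C\NC(=O)[C@H](O)C(C)(C)CO`, gives "not determined" (no result reported) in this assay, so no result is reported for it. Compound 2, with the structure `COC(=O)/C=C\NC(=O)[C@@H](O)C(C)(C)CO`, gives -20%. Compound 3, with the structure `CC(C)(CO)[C@@H](O)C(=O)N/C=C/C(=O)OCc1ccccc1`, gives 19%, which is the highest of the two numbers reported and lies beyond the usual scatter above compound 2. Going by the values given here, the only difference between compound 1 and compound 2 is the fact that compounds 1 and 2 differ only in the configuration as drawn, so the read-out is sensitive to how the molecule is drawn in space even when all groups are the same.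

Compound 4, with the structure `COC(=O)/C=C/NC(=O)[C@H](O)C(C)(C)CO`, has not yet been tested in this assay. It differs from compound 3 in one place: hydrogen in place of phenyl on a saturated chain carbon bound to an oxygen next to a carbonyl group. Among the compounds with values here, no measured pair shows this particular change, so its effect must be guessed. Given that compound 2 gives -20% while compound 3 gives 19%, the read-out in this series moves around zero, and compound 4 is expected to land between them. The step from compound 3 to compound 4 is estimated as a number 17 percentage points lower from compound 3 to compound 4 (beyond the scatter), a modest drop. Compound 4 is therefore expected to give about 2%, within a range of -22% to 26%.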

Compound 4, a percentage reported as inhibition, at one concentration (the size of the read-out at that concentration, not a potency): 4%
The estimate for compound 4 lay 2 percentage points below the measured number, within the range that was stated.
By their numbers in this assay, from the lowest: compound 2; then compound 4; then compound 3.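

In this assay, going by these compounds alone, putting hydrogen in place of phenyl on a saturated chain carbon bound to an oxygen next to a carbonyl group, which turns benzyl into methyl, gives a number 15 percentage points lower from compound 3 to compound 4 (beyond the scatter); this is the first comparison that changes a single group, and it shows that the read-out responds to this change at this position. The read-out also moves with no change in atoms or bonds, as a number 24 percentage points higher from compound 2 to compound 4 (beyond the scatter) shows, with both a stereocentre and a double bond drawn differently: the fact that compounds 2 and 4 differ only in the configuration as drawn. These two differences occur together, so this step cannot be assigned to the stereocentre or to the double bond alone.

On these data alone, compound 1 gives "not determined" (no result reported), so the separate contributions of the stereocentre and the double bond remain open. Also open, as far as these compounds go, is how the read-out would respond to other groups at this end of the molecule, such as a longer chain on the ester oxygen or a carboxylic acid in place of the ester, since only benzyl and methyl esters appear here.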